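A few compounds are considered here, and "the series" means these few. Any claim that something is new, unique, unknown or untested is made for them only; others in the source may bear on it.

In a functional assay on A549 cells (Homo sapiens) for antiproliferative activity, read by MTT assay, with a stated time of 48 h (on this read-out higher numbers stand for weaker inhibition and lower numbers for stronger inhibition), the series is anchored by compound 1 `N#CC1=C(N)Oc2c(N)cc3nc4ccccc4nc3c2C12C(=O)N(Cc1cnnn1-c1ccccc1Br)c1ccccc12`, which gives 27400 nM. Compound 2 `Cc1ccc(Cl)cc1-n1nncc1CN1C(=O)C2(C(C#N)=C(N)Oc3c(N)cc4nc5ccccc5nc4c32)c2ccccc21` returns only a limit of the assay, > 50000 nM, not a number. Compound 3 `N#CC1=C(N)Oc2c(N)cc3nc4ccccc4nc3c2C12C(=O)N(Cc1cnnn1-c1ccc([N+](=O)[O-])cc1[N+](=O)[O-])c1ccccc12` likewise returns only a limit in this assay, > 50000 nM. the limit of > 50000 nM in this assay, at which 2 of the 3 values shown sit, is where both of these values rest. Away from compound 1 the steps read an at least 1.8-fold higher number from compound 1 to compound 2 (0.26 log units; that floor lies within the scatter) and an at least 1.8-fold higher number from compound 1 to compound 3 (0.26 log units; that floor lies within the scatter); the comparison a step that the two limits leave unreadable from compound 2 to compound 3 cannot be read, two limits facing each other. Compound 3 therefore stands at the upper edge of what this assay reports, with no number of its own.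

Compound 4 `N#CC1=C(N)Oc2c(N)cc3nc4ccccc4nc3c2C12C(=O)N(Cc1cnnn1-c1c(Cl)cc(Cl)cc1Cl)c1ccccc12` differs from compound 3 by 2,4,6-trichlorophenyl in place of 2,4-dinitrophenyl on an aromatic nitrogen. The measured steps that bear on this change are the two that leave compound 1, namely an at least 1.8-fold higher number from compound 1 to compound 2 (0.26 log units; that floor lies within the scatter) and an at least 1.8-fold higher number from compound 1 to compound 3 (0.26 log units; that floor lies within the scatter); both end at the limit, and compound 2 with its 5-chloro-2-methylphenyl group already sits among them. Nothing in the measured steps points back toward the number of compound 1. The expected step is an at least 1.1-fold lower number from compound 3 to compound 4 (0.04 log units; that floor lies within the scatter), which amounts to no move beyond the scatter. Compound 4 is expected in this assay at 45000 nM, with a range from 20000 nM to 100000 nM.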

Compound 4, half-maximal inhibitory concentration: > 50000 nM
Compound 4: only a limit was reported (the forecaster's own chance of this, stated with the estimate: 55%); middle value at least 1.1-fold (0.04 log units) away from the limit.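

In this assay compound 4 gives > 50000 nM, which is a limit of the assay and not a number. Among the compounds shown here, the only readable new step is an at least 1.8-fold higher number from compound 1 to compound 4 (0.26 log units; that floor lies within the scatter), while the steps linking compound 4 to compound 2 and compound 3 cannot be read, since each sets two limits against each other. The new point concerns the group on the aromatic nitrogen: 2,4,6-trichlorophenyl, with only chlorine on the ring and no hydrogen-bond acceptors, gives no number, just as 2,4-dinitrophenyl, with its nitro groups and 4 hydrogen-bond acceptors, gave none, so compound 1 remains the only compound with a number and the series gathers at one place: the limit of > 50000 nM in this assay, at which 3 of the 4 values shown sit.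

From the compounds shown here alone, with three of the four compounds at a limit, any ordering among compound 2, compound 3 and compound 4 stays open, as does how far each lies from compound 1. Also open, going by these compounds, is whether a plain phenyl, an aminophenyl or a carboxyphenyl group on that nitrogen would bring the read-out back to a number, which would show whether the 2-bromophenyl of compound 1 holds any special place.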